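Working notes on three measured compounds and one pending

The source may report more compounds than this note shows. Statements on the series, on what has been measured and on what is new or still open speak of the compounds shown alone.

Measured so far in a functional assay on the whole organism with Rattus norvegicus as the target, in the maximal electroshock model; on this read-out higher numbers stand for an effect only at larger amounts of compound and lower numbers for an effect already at smaller amounts:

- compound 1 `CN(C)c1ncnc2c1ncn2Cc1c(F)cccc1F` gives 2.2 mg/kg
- compound 2 `CNc1ncnc2c1ncn2Cc1cccc(F)c1F` gives 18 mg/kg
- compound 3 `CCNc1ncnc2c1ncn2Cc1ccccc1F` gives 4.9 mg/kg

Compound 3 sits second highest of the three numbers. Its nearest neighbour is compound 1, which gives a lower number, and the gap lies beyond the usual scatter. Compound 2 is furthest, with a higher number, again beyond the scatter. No two of these compounds differ in one place only, so nothing here isolates the effect of a single change.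

Compound 4 `Fc1ccccc1Cn1cnc2c(N3CCC3)ncnc21` has not yet been measured. It differs from compound 3 in one place: azetidin-1-yl in place of ethylamino on an aromatic carbon. The change keeps the fluorobenzyl part and the shared core of compound 3 untouched.

Among the measured compounds shown here, no measured pair shows what replacing an ethylamino with a cyclic amine does in this assay. Compound 1, which carries a dimethylamino in the same position and gives 2.2 mg/kg, shows that a substituent with no amine hydrogen is compatible with a low number, though its benzyl part also differs. The step is therefore expected to be small, at most within the scatter, with a slight lean toward a lower number: the expected step is a 1.2-fold lower number from compound 3 to compound 4 (0.09 log units; within the scatter). Compound 4 is estimated at 4 mg/kg, with a range from 1.5 mg/kg to 12 mg/kg.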

Compound 4, dose for half-maximal effect: > 50 mg/kg
Compound 4: a limit, no number; the forecaster's own chance of this, stated with the estimate: 5%; at least 12-fold (1.09 log units) between middle value and limit.
By their numbers in this assay, from the lowest: compound 1; then compound 3; then compound 2. At a limit, above all of these: compound 4.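

In this assay, azetidin-1-yl in place of ethylamino on this aromatic carbon, the one place where the two structures differ, gives an at least 10-fold higher number from compound 3 to compound 4 (1.00 log units; beyond the scatter). Among the compounds shown here, this is the first step that isolates a single change, and it shows that the read-out responds strongly to the amine group at this position, opposite the ring nitrogen, while the fluorobenzyl part and the shared core stay fixed. The reading for compound 4 is a limit of the assay and not a number, so the full size of the step stays unknown: the limit of > 50 mg/kg in this assay, at which 1 of the 4 values shown sits.

The step does not separate two things that change together: the hydrogen-bond donor of ethylamino leaves, and a four-membered non-aromatic ring enters. On these data alone, whether the ring as such or this particular ring size goes with the higher number stays open, and a pyrrolidin-1-yl or a propylamino chain on the same carbon, with the fluorobenzyl part kept, would bear on that question.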